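A few compounds are considered here, and "the series" means these few. Any claim that something is new, unique, unknown or untested is made for them only; others in the source may bear on it.

Measured so far:
- compound 1 `CCCCc1[nH]c(=O)c(-c2nnc(Cc3ccccc3)o2)c(O)c1-c1c(OC)cccc1OC`: 53%
- compound 2 `COc1cccc(OC)c1-c1c(C2CC2)[nH]c(=O)c(-c2nnc(Cc3ccc(Cl)cc3)o2)c1O`: 51%

In an ADME assay on microsomes from liver (Rattus norvegicus) for metabolic stability, read by mass spectrometry, using NADPH, with a stated time of 10 min (a lower number here means that less of the compound is left, a higher number that more of the compound is left), compound 1 gives 53% and compound 2 gives 51%. The two numbers lie within the scatter of each other, so on this read-out nothing separates compound 2 from compound 1; compound 2 simply sits alongside it. Among the measured compounds shown here, no pair of measured compounds differs in a single place, so no measured step is available to calibrate a structural change.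

Compound 3 `COCCc1[nH]c(=O)c(-c2nnc(Cc3ccc(Cl)cc3)o2)c(O)c1-c1c(OC)cccc1OC` has not yet been measured in this assay. It differs from compound 2 by 2-methoxyethyl in place of cyclopropyl on an aromatic carbon. For the measured compounds named here, none of the measured compounds carries this change, so the measured numbers say nothing direct about it. For compound 3 in this assay the expected step of a number 6 percentage points lower from compound 2 to compound 3 (within the scatter) is small, within the scatter or only a little beyond it, and downward if anything. Compound 3 is therefore estimated at 45%, with a range from 25% to 65%.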

Compound 3, percent of the compound remaining: 73%
Compound 3: the middle estimate sits 28 percentage points below what was measured; measured number outside the range, above it.
By their numbers in this assay, from the lowest: compounds 2 and 1 (each within the scatter of the next); then compound 3.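

In this assay, 2-methoxyethyl in place of cyclopropyl on the aromatic carbon next to the ring nitrogen gives a number 22 percentage points higher from compound 2 to compound 3 (beyond the scatter). Among the compounds shown here, this is the only single-place step so far, and it shows that the percent of compound remaining responds to the group at this position while the rest of the structure stays fixed. No measurement at hand bears on why the number rises.

Still open, on these data alone, is whether the step follows the ether oxygen of the chain or the loss of the three-membered ring, a question that a plain propyl chain at this position could help settle. Also open, as far as these compounds go, is whether a longer ether chain, an amine or a carboxylic acid in the same place would move the number in the same direction.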